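Chloro-to-hydrogen step on the aryl amide of compound 1

This account rests on a few compounds, and the source may have more. Where it says the series, first, only, none or still open, it means among the compounds named here.

Measured compounds and values:
compound 1 `COc1ccc(CNC(=O)CSc2nc3ccc(NC(=O)c4ccc(Cl)cc4)cc3s2)cc1` 7400 nM
compound 2 `O=C(CSc1nc2ccc(NC(=O)CCl)cc2s1)NCc1ccccc1` 1100 nM
compound 3 `CC(=O)Nc1ccc2nc(SCC(=O)NCc3ccccc3)sc2c1` 9200 nM

In a functional assay on HepG2 cells (Homo sapiens) for cytotoxicity, read by MTT assay, with a stated time of 48 h (on this read-out higher numbers stand for weaker inhibition and lower numbers for stronger inhibition), compound 1 stands second highest of the three numbers; compound 3 sits within the scatter of it, whereas compound 2 lies beyond the scatter with a lower number. Compound 4 `COc1ccc(CNC(=O)CSc2nc3ccc(NC(=O)c4ccccc4)cc3s2)cc1` is not yet measured. It differs from compound 1 by hydrogen in place of chloro on an aromatic carbon. For the measured compounds named here, the only measured step that also removes a chlorine is an 8.4-fold higher number from compound 2 to compound 3 (0.92 log units; beyond the scatter), but there the chlorine sits on a saturated chain carbon next to a carbonyl, not on an aromatic ring, so it bears on the present step only loosely. For compound 4 the expected step is a 1.2-fold higher number from compound 1 to compound 4 (0.09 log units; within the scatter), most likely nothing beyond the scatter. The estimate for compound 4 is 9000 nM, with a range from 4000 nM to 20000 nM.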

Compound 4, half-maximal inhibitory concentration: 12700 nM
The estimate for compound 4 lay 1.4-fold (0.15 log units) below the measured number; measured number inside the range.
By their numbers in this assay, from the lowest: compound 2; then compounds 1, 3 and 4 (each within the scatter of the next).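

In this assay, the step of a 1.7-fold higher number from compound 1 to compound 4 (0.23 log units; within the scatter) shows that at this place on the benzamido group, hydrogen and chloro cannot be told apart. The chlorine therefore does not behave here as it does on the saturated chain carbon, where the step of an 8.4-fold higher number from compound 2 to compound 3 (0.92 log units; beyond the scatter) is readable. Nothing measured on hand accounts for this result.

As far as these compounds go, whether an amine or a carboxylic acid at this aromatic carbon would move the number beyond the scatter remains open.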